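The source may report more compounds than this note shows. Statements on the series, on what has been measured and on what is new or still open speak of the compounds shown alone.

Compound 1 `Fc1ccc(C2=NN(C3=NC(c4ccccc4)CS3)C(c3ccc4ccccc4c3)C2)cc1` and compound 2 `Cc1ccc(C2=NN(C3=NC(c4ccccc4)CS3)C(c3ccc4ccccc4c3)C2)cc1C` share one core, and in a functional assay on BGC-823 cells (Homo sapiens) for inhibition, read by CCK-8 assay, with a stated time of 48 h (a lower number here means a stronger inhibitor, a higher number a weaker inhibitor), compound 1 gives 17300 nM while compound 2 gives 6570 nM. The change between them, (3,4-dimethylphenyl in place of 4-fluorophenyl on a carbon with a double bond to nitrogen), brought a 2.6-fold lower number from compound 1 to compound 2 (0.42 log units; beyond the scatter). Compound 3 `O=C1CSC(N2N=C(c3ccc(F)cc3)CC2c2ccc3ccccc3c2)=N1` carries a different group on the ring nitrogen, (a group of 6 heavy atoms (3 carbon, 1 nitrogen, 1 oxygen, 1 sulfur; one five-membered non-aromatic ring with 2 hetero atoms) in place of a group of 11 heavy atoms (9 carbon, 1 nitrogen, 1 sulfur; one five-membered non-aromatic ring with 2 hetero atoms, one six-membered aromatic ring of carbon only), on an amine nitrogen in a ring), and in this assay compound 3 gives 14900 nM, which is a 1.2-fold lower number from compound 1 to compound 3 (0.06 log units; within the scatter). Compound 4 `Cc1ccc(C2=NN(C3=NC(=O)CS3)C(c3ccc4ccccc4c3)C2)cc1C` repeats the same kind of change on the core of compound 3, (3,4-dimethylphenyl in place of 4-fluorophenyl on a carbon with a double bond to nitrogen); around the place it stands two ring bonds from the ring atom that bears a group of 6 heavy atoms, whereas in compound 2 the place stood two ring bonds from the ring atom that bears a naphthalen-2-yl group. In this assay compound 4 is expected to show a 2.6-fold lower number from compound 3 to compound 4 (0.42 log units; beyond the scatter), an expectation resting on the earlier step of a 2.6-fold lower number from compound 1 to compound 2 (0.42 log units; beyond the scatter). The estimate for compound 4 is 5700 nM, expected between 2500 nM and 13000 nM.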

Compound 4, half-maximal inhibitory concentration: 6020 nM
Compound 4: middle estimate off by 1.1-fold (0.02 log units), on the low side; the measured number falls inside the stated range.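

In this assay, 3,4-dimethylphenyl in place of 4-fluorophenyl gave a 2.5-fold lower number from compound 3 to compound 4 (0.39 log units; beyond the scatter), so the change carried over to the second core with nearly the same size: the same change on two cores in this assay, a 2.6-fold lower number (0.42 log units; beyond the scatter) from compound 1 to compound 2 and a 2.5-fold lower number (0.39 log units; beyond the scatter) from compound 3 to compound 4, 1.1-fold (0.03 log units) apart, within the scatter of two such steps. Exchanging the group on the ring nitrogen gave a 1.1-fold lower number from compound 2 to compound 4 (0.04 log units; within the scatter), and that exchange also behaved alike with either group present: the same change on two cores in this assay, a 1.2-fold lower number (0.06 log units; within the scatter) from compound 1 to compound 3 and a 1.1-fold lower number (0.04 log units; within the scatter) from compound 2 to compound 4, 1.1-fold (0.03 log units) apart, within the scatter of two such steps. This shows that the two changes combine consistently across these four compounds, but two cores and one pair of groups do not show that this holds across the wider series.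

The compounds shown leave open whether an amine, a carboxylic acid or a longer chain in place of 3,4-dimethylphenyl would also carry over between the cores. From the compounds shown here alone, it also remains open whether the agreement would survive replacing the naphthalen-2-yl group with a pyridine ring.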